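Vinyl for Ethynyl: Carrying One Step to a Second Core

This account rests on a few compounds, and the source may have more. Where it says the series, first, only, none or still open, it means among the compounds named here.

Compound 1 `C#Cc1cncc(C#Cc2csc(C)n2)c1` gives 19.2 nM in a functional assay on CHO cells for agonist activity at metabotropic glutamate receptor 5 (Homo sapiens), read by inositol phosphate accumulation; on this read-out lower numbers stand for stronger inhibition and higher numbers for weaker inhibition.
Compound 2 `C=Cc1cncc(C#Cc2csc(C)n2)c1` gives 2.01 nM in this assay.
Compound 3 `C#Cc1ccc(C#Cc2csc(C)n2)cn1` gives 2950 nM in this assay.

The change vinyl in place of ethynyl on an aromatic carbon produced the step of a 9.6-fold lower number from compound 1 to compound 2 (0.98 log units; beyond the scatter). Compound 3 holds the same atoms as compound 1, joined differently; the difference between the two cores is not broken down here, and compound 3 stands highest of the three numbers in this assay.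

Compound 4 `C=Cc1ccc(C#Cc2csc(C)n2)cn1` is not yet measured. It differs from compound 3 by vinyl in place of ethynyl on an aromatic carbon. Within the data shown here, this is the same kind of change as the one from compound 1 to compound 2, but not the same: there the place was two atoms from the ring nitrogen and meta to a group of 8 heavy atoms, here it is next to the ring nitrogen and para to a group of 8 heavy atoms.

The expectation rests on the step of a 9.6-fold lower number from compound 1 to compound 2 (0.98 log units; beyond the scatter) made by the same kind of change, tempered by the differing place. On that basis compound 4 is expected to show a 4.9-fold lower number from compound 3 to compound 4 (0.69 log units; beyond the scatter). Compound 4 is estimated at 600 nM, with a range from 200 nM to 2000 nM.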

Compound 4, half-maximal inhibitory concentration: > 10000 nM
Compound 4 gave a limit, no number (the forecaster's own chance of this, stated with the estimate: 5%); middle value at least 16-fold (1.22 log units) from the limit.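

In this assay, compound 4 gives > 10000 nM, which is a limit of the assay and not a number. Even with only a limit to read, vinyl in place of ethynyl gives an at least 3.3-fold higher number from compound 3 to compound 4 (0.53 log units; beyond the scatter), so the gain seen on the core of compound 1 did not carry to the core of compound 3, and the step went the opposite way: the same change on two cores in this assay, a 9.6-fold lower number (0.98 log units; beyond the scatter) from compound 1 to compound 2 and an at least 3.3-fold higher number (0.53 log units; beyond the scatter) from compound 3 to compound 4, at least 32-fold (1.51 log units) apart, beyond the scatter of two such steps This shows that, across these two cores, the direction of the change cannot be assumed to hold, but it does not show how large the loss truly is, nor whether the core itself or the differing place of the group accounts for the gap, and the size of the step stays open at its upper end: the limit of > 10000 nM in this assay, at which 1 of the 4 values shown sits.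

The compounds shown leave open how an ethyl group or a primary amine on that same aromatic carbon would read on either core. They also leave open whether the vinyl step would go up or down on any third core.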